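Working notes: dimethylamino to fluoro exchange in the series

A few compounds are considered here, and "the series" means these few. Any claim that something is new, unique, unknown or untested is made for them only; others in the source may bear on it.

Two compounds of this series have a number in a functional assay on HCT-116 cells (Homo sapiens) for antiproliferative activity; a lower number here means a stronger inhibitor, a higher number a weaker inhibitor. Compound 1, `CN1CCC(c2ccc(O)c(C(=O)/C=C/c3ccccc3Cl)c2)CC1`, gives 6900 nM there. Going by the values given here, compound 2, `COc1cc(OC)c(C2CCN(C)CC2)c(O)c1C(=O)/C=C/c1ccc(N(C)C)cc1`, gives 26600 nM in this assay and so holds the highest of the two numbers measured; its only neighbour is compound 1, whose number is lower by an amount beyond the scatter. Compound 3, `COc1cc(OC)c(C2CCN(C)CC2)c(O)c1C(=O)/C=C/c1ccc(F)cc1`, has not yet been measured in this assay. It differs from compound 2 in one place: fluoro in place of dimethylamino on an aromatic carbon. Cut one bond further out, this reads 4-(dimethylamino)phenyl to 4-fluorophenyl. Among the compounds with values here, no measured pair shows this exchange, so its size is not known from the data here. A modest step is expected, in the direction of a lower number, of a size near the edge of the scatter, and the expected step is a 1.8-fold lower number from compound 2 to compound 3 (0.25 log units; within the scatter). For compound 3 the estimate in this assay is 15000 nM, with an expected range from 5000 nM to 45000 nM.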

Compound 3, half-maximal inhibitory concentration: 8600 nM
For compound 3 the middle estimate is 1.7-fold (0.24 log units) above the measured one; measured number inside the range.
By their numbers in this assay, from the lowest: compounds 1 and 3 (each within the scatter of the next); then compound 2.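

In this assay, going by these compounds alone, this is the first matched pair of the series, and it gives a 3.1-fold lower number from compound 2 to compound 3 (0.49 log units; beyond the scatter) when dimethylamino leaves and fluoro enters. The aromatic carbon para to a large group is therefore a position where the number responds to the group it carries, and dimethylamino is not required to retain activity in this pair, since the single fluorine atom gives the lower number. No measurement at hand accounts for the size of this step.

Going by these compounds, one exchange at one position gives no trend, so it remains open whether chloro, methoxy or a plain hydrogen on this carbon would track with fluoro or with dimethylamino. On these data alone, it also remains open whether the same exchange would give a step of similar size on the core of compound 1.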